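The compounds below may be only part of what the source reports. "The series", "measured", "known", "first", "only" and "open" are said of these compounds alone.

The compounds share one core and differ only at a single aromatic carbon on it. Compound 1 `COc1ccc(F)cc1CNCCCNc1ccnc2cc(Oc3ccc(F)cc3)ccc12` and compound 2 `CCC(CC)c1ccc2c(NCCCNCc3cc(F)ccc3OC)ccnc2c1` have both been measured in a physicochemical assay for acid dissociation. Compound 1 gives 9.28 in this assay, and compound 2 gives 9.47 in this assay. Compound 2 stands highest of the two numbers, with compound 1 nearest, though the step of a number 0.19 log units higher from compound 1 to compound 2 (within the scatter) lies within the scatter, so the two cannot be told apart. Compound 3 `COc1ccc(-c2ccc3c(NCCCNCc4cc(F)ccc4OC)ccnc3c2)cc1` has not yet been measured. It differs from compound 2 by 4-methoxyphenyl in place of pentan-3-yl on an aromatic carbon. Among the compounds with values here, the only measured step that bears on this carbon, a number 0.19 log units higher from compound 1 to compound 2 (within the scatter), lies within the scatter, so no step beyond the scatter is expected from a further swap at the same carbon. Compound 3 is therefore expected to give 9.4 in this assay, between 9 and 9.8. The step this estimate means for compound 3 is a number 0.07 log units lower from compound 2 to compound 3 (within the scatter).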

Compound 3, acid dissociation constant: 9.47
The estimate for compound 3 lay 0.07 log units below the measured number; the range from low to high includes it.
By their numbers in this assay, from the lowest: compounds 1, 2 and 3 (each within the scatter of the next).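

In this assay this aromatic carbon has now carried three different groups, and all three numbers lie within the scatter of one another: 4-methoxyphenyl in place of pentan-3-yl gives no change at the digits printed from compound 2 to compound 3 (within the scatter) and 4-methoxyphenyl in place of 4-fluorophenoxy gives a number 0.19 log units higher from compound 1 to compound 3 (within the scatter) in the same assay. Within the data shown here, the earlier compounds allowed only one comparison at this carbon, whereas these results show that a third group, one with a single six-membered aromatic ring of carbon only, also cannot be told apart from the other two. No measurement shown here offers an explanation for this result.

From the compounds shown here alone, it remains open whether a different kind of group on this carbon, such as an amine, a carboxylic acid or a nitrile, would give a step beyond the scatter. The compounds shown also leave open how the number responds to a change elsewhere on the shared structure, such as a longer chain.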